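Halogen swap at the double-bonded ring carbon

The source may report more compounds than this note shows. Statements on the series, on what has been measured and on what is new or still open speak of the compounds shown alone.

Measured so far:
compound 1 `O=C1[C@@]2(CO)C=C(Br)C(CC2c2ccccc2)[C@]12CO2` — > 50000 nM
compound 2 `C[C@@]12COC[C@]13C=C(Br)C(C2)[C@]1(CO1)C3=O` — > 50000 nM

Both measured compounds carry a bromine on a double-bonded ring carbon of the shared core. In an ADME assay on Huh-7 cells (Homo sapiens) for cytotoxicity (a higher number here means that more compound is tolerated, a lower number that less compound is tolerated), compound 1 gives > 50000 nM, which is a limit of the assay and not a number. Compound 2 likewise gives > 50000 nM in this assay, again only a limit. Among the measured compounds shown here, compound 1 thus stands exactly where the one other value stands; the limit of > 50000 nM in this assay, at which 2 of the 2 values shown sit, covers everything measured so far, and no step between measured compounds can be drawn.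

Compound 3 `O=C1[C@@]2(CO)C=C(I)C(CC2c2ccccc2)[C@]12CO2` is the next candidate. It differs from compound 1 by iodo in place of bromo on a double-bonded ring carbon. With both measured values sitting at the limit, the expectation for the step from compound 1 to compound 3 is none beyond the scatter, and a number no higher from compound 1 to compound 3 (the limit leaves the size open) reflects that expectation. Compound 3 is therefore expected to give about 50000 nM in this assay, within 25000 nM to 100000 nM, most likely again reported only as a limit.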

Compound 3, half-maximal cytotoxic concentration: 27100 nM
Compound 3: middle estimate off by 1.8-fold (0.27 log units), on the high side, and the stated range covers the measured number.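

In this assay, among the compounds shown here, compound 3 gives 27100 nM, the first reading that is a number. From the compounds shown here alone, compound 1 gives > 50000 nM, which is a limit of the assay and not a number, so iodo in place of bromo on a double-bonded ring carbon can only be read as a floor: the step is an at least 1.8-fold lower number from compound 1 to compound 3 (0.26 log units; that floor lies within the scatter), and its true size stays open. Compound 3 therefore gives the series its only numerical reference point, with everything else at the ceiling: the limit of > 50000 nM in this assay, at which 2 of the 3 values shown sit.

Going by these compounds, whether chloro, a methyl group or a nitrile on this double-bonded ring carbon would read as a number or as a limit remains open. Equally open, on these data alone, is whether iodo in place of bromo would give a number on the core of compound 2.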